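Amino to Iodo Exchange: Working Notes Toward Compound 4

The compounds below may be only part of what the source reports. "The series", "measured", "known", "first", "only" and "open" are said of these compounds alone.

Compound 2 `CC(/C=N/Nc1ccc([N+](=O)[O-])cc1)=N\NC(=O)c1ccccc1N` gives 4900 nM in a functional assay on cells (Splenocyte, Mus musculus, strain BALB/c) for inhibition, read by scintillation counting and thymidine incorporation, with a stated time of 72 h; a higher number here means a weaker inhibitor, a lower number a stronger inhibitor. Compound 1 `CC(/C=N/N(C)c1ccc([N+](=O)[O-])cc1)=N\NC(=O)c1ccc(N)cc1` returns only a limit of the assay, > 12000 nM, in this assay. Compound 3 `CC(/C=N/Nc1ccc([N+](=O)[O-])cc1)=N\NC(=O)c1ccccc1` likewise returns a limit, > 12000 nM, in this assay. On the numbers shown, compound 2 therefore holds the only measured value; the other two compounds rest at a boundary, and the limit of > 12000 nM in this assay, at which 2 of the 3 values shown sit, marks where they sit.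

For the measured compounds named here, the one measured step that can be read is an at least 2.4-fold higher number from compound 2 to compound 3 (0.38 log units; beyond the scatter). It is at least modest, lies beyond the scatter, and runs toward weaker inhibition.

Compound 4 `CC(/C=N/Nc1ccc([N+](=O)[O-])cc1)=N\NC(=O)c1ccccc1I` differs from compound 2 in one place: iodo in place of amino on an aromatic carbon. The step of an at least 2.4-fold higher number from compound 2 to compound 3 (0.38 log units; beyond the scatter) bears on this change; in both, the amino leaves. Going by the values given here, compound 4 further brings in iodo at that place, and no measured pair here tests what the iodo itself adds, so the expectation rests on the loss seen for compound 3 alone. The expected step is a 2.4-fold higher number from compound 2 to compound 4 (0.39 log units; beyond the scatter), toward a higher number in this assay. Compound 4 is estimated at 12000 nM, with a range from 4000 nM to 40000 nM. A fair chance remains that only a limit is reported.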

Compound 4, half-maximal inhibitory concentration: 2980 nM
Estimate against measurement, compound 4: 4.0-fold (0.60 log units) above; measured number below the stated range.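

At this place on the six-membered aromatic ring, the amino can be exchanged without a change that the assay can resolve. With iodo in its stead, the step reads a 1.6-fold lower number from compound 2 to compound 4 (0.22 log units; within the scatter) in this assay, although the hydrogen-bond donor that leaves with the amino does not return with the iodo, so compound 2 and compound 4 cannot be placed in any order. The hydrogen comparison now has a second member, since an at least 4.0-fold lower number from compound 3 to compound 4 (0.60 log units; beyond the scatter) adds to the step seen with the amino and shows that both groups at this place separate from hydrogen. Compound 3 stands at a limit of the assay and not at a number, as does compound 1: the limit of > 12000 nM in this assay, at which 2 of the 4 values shown sit.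

From the compounds shown here alone, whether a chlorine, a methoxy or a carboxylic acid at this place would join compound 2 and compound 4 or fall to the limit stays open, and so does what iodo would give elsewhere on this ring. The compounds shown also give no means of telling why hydrogen separates from both amino and iodo at this place.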